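This account rests on a few compounds, and the source may have more. Where it says the series, first, only, none or still open, it means among the compounds named here.

Measured in an ADME assay on Raji cells (Homo sapiens) for cytotoxicity, with a stated time of 72 h; on this read-out higher numbers stand for an effect only at larger amounts of compound and lower numbers for an effect already at smaller amounts:
Compound 1 `O=C(Nc1ccc(F)c(-c2nc3ccccc3s2)c1)c1cc([N+](=O)[O-])ccc1Cl`: > 25000 nM, a limit.
Compound 2 `O=C(Nc1cccc(-c2nc3ccccc3s2)c1)c1cc([N+](=O)[O-])ccc1Cl`: > 27000 nM, a limit.
Compound 3 `O=C(Nc1cccc(-c2ccccc2)c1)c1cc([N+](=O)[O-])ccc1Cl`: > 27000 nM, a limit.

Compound 2 has no number, only a limit, and it shares (the limit of > 27000 nM in this assay, at which 2 of the 3 values shown sit). The remaining value is the limit of > 25000 nM in this assay, at which 1 of the 3 values shown sits.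

Compound 4 `O=C(Nc1cc(-c2nc3ccccc3s2)ccc1Cl)c1cc([N+](=O)[O-])ccc1Cl` carries chloro in place of hydrogen on an aromatic carbon of compound 2, para to a 1,3-benzothiazol-2-yl group: chloro in place of hydrogen on an aromatic carbon.

The nearest measured change is the loss of fluoro in a step that the two limits leave unreadable from compound 1 to compound 2. The other measured change, phenyl for 1,3-benzothiazol-2-yl, is a step that the two limits leave unreadable from compound 2 to compound 3. Neither gives a size, so no step beyond the scatter is expected in this assay.

The expected step is an at least 1.0-fold lower number from compound 2 to compound 4 (0.03 log units; that floor lies within the scatter).

Compound 4 is estimated at 25000 nM, with an expected range of 9000 nM to 35000 nM.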

Compound 4, half-maximal effective concentration: > 25000 nM
Compound 4: a limit, no number; the forecaster's own chance of this, stated with the estimate: 75%; the middle value sits exactly at the limit.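

In this assay compound 2 and compound 4 each stand only as a limit, and the step for chloro in place of hydrogen cannot be read. The compounds shown leave open at what concentration any of them reaches a half-maximal effect.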